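The source may hold more compounds than are shown below. What is called first, only, known or untested is meant among the compounds shown, and "the series" means these compounds.

Measured so far in a functional assay on the whole organism (strain Wister albino) for inhibition, with Rattus norvegicus as the target, read by paw edema, with stated times of 1 h and 2 h, at a dose of 50 mg/kg by the intraperitoneal route; a higher number here means more inhibition at the dose given (going by the name of the read-out), a lower number less inhibition:

compound 1 , `CCOC(=O)c1c(-c2ccc(Cl)c(Cl)c2)cc(-c2ccccc2)nc1Nc1ccc(C)cc1`: 62.1%
compound 2 , `CCOC(=O)c1c(-c2ccc(Cl)cc2)cc(-c2ccccc2)nc1Nc1ccc(Cl)cc1`: 40.6%

Compound 2 stands lowest of the two numbers in this assay; its nearest neighbour is compound 1, whose number lies higher by a margin beyond the scatter. Among the compounds with values here, the two differ in two places at once, on the aryl group carried by the shared core and on the anilino group, so no single step between them can be read.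

Compound 3, `CCOC(=O)c1c(-c2ccc(Cl)c(Cl)c2)cc(-c2ccccc2)nc1Nc1ccc(Cl)cc1`, takes the 3,4-dichlorophenyl group of compound 1 while keeping the 4-chloroanilino group of compound 2. Against compound 2 the difference is chloro in place of hydrogen on an aromatic carbon.

Within the data shown here, no measured step isolates this change. Compound 1, which also carries the 3,4-dichlorophenyl group, gives 62.1%, while compound 2 gives 40.6%, but the anilino group differs as well, so only a loose expectation follows. A moderate rise is expected for compound 3, of about a number 9.4 percentage points higher from compound 2 to compound 3 (within the scatter), with the direction uncertain and the size near the scatter. Compound 3 is estimated at 50%, within 35% to 65%.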

Compound 3, a percentage reported as inhibition, in the whole organism at one dose (the size of the read-out at that dose, not a potency): 61.9%
Compound 3: middle estimate off by 11.9 percentage points, on the low side; the measured number falls inside the stated range.
By their numbers in this assay, from the lowest: compound 2; then compounds 3 and 1 (each within the scatter of the next).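

In this assay, chloro in place of hydrogen on an aromatic carbon, the change from 4-chlorophenyl to 3,4-dichlorophenyl, can now be read as a single step: a number 21.3 percentage points higher from compound 2 to compound 3 (beyond the scatter). A second single step, chloro in place of methyl on an aromatic carbon, reads a number 0.2 percentage points lower from compound 1 to compound 3 (within the scatter), so among these three compounds the gap between compound 1 and compound 2, which could not be divided before, goes with the 3,4-dichlorophenyl group, and exchanging methyl for chloro does not separate compound 1 from compound 3. No measurement bears on the reason for either step.

Going by these compounds, whether this step belongs to chloro in particular or would also appear with another group on that aromatic carbon, such as fluoro, methoxy or an amine, remains open, and the step rests on a single pair of compounds carrying the 4-chloroanilino group. Also open, on these data alone, is how the ethyl ester on the shared core contributes, for example against a carboxylic acid, and how these read-outs at one dose would compare across other doses.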